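Dropping isopropylcarbonyl from compound 1: working notes

The compounds below may be only part of what the source reports. "The series", "measured", "known", "first", "only" and "open" are said of these compounds alone.

In a functional assay on HeLa cells (Homo sapiens) for inhibition, read by trypan blue exclusion, with a stated time of 72 h (on this read-out lower numbers stand for stronger inhibition of growth and higher numbers for weaker inhibition of growth), compound 1 (`CC/C(=C(\c1ccccc1)c1ccc(NC(=O)C(C)C)cc1)c1ccccc1`) gives > 30000 nM as a limit of the assay and not a number. Compound 2 (`CC/C(=C(\c1ccc(O)cc1)c1ccc(NC(=O)C(C)C)cc1)c1ccccc1`) gives 9900 nM in this assay as a measured number. Among the compounds with values here, the one measured step is an at least 3.0-fold lower number from compound 1 to compound 2 (0.48 log units; beyond the scatter) for hydroxy in place of hydrogen on an aromatic carbon. Compound 3 (`CC/C(=C(\c1ccccc1)c1ccc(N)cc1)c1ccccc1`) carries a different change, hydrogen in place of isopropylcarbonyl on a nitrogen on an aromatic ring in words hydrogen in place of isopropylcarbonyl on a nitrogen on an aromatic ring. The hydroxy step sits elsewhere and bears only loosely, so no measured step sizes this change directly. With compound 1 resting on the limit > 30000 nM in this assay only a small move toward a lower number is expected, possibly none beyond the scatter. The expected step is an at least 1.2-fold lower number from compound 1 to compound 3 (0.07 log units; that floor lies within the scatter) and remains uncertain. Compound 3 is estimated at 25000 nM within a range of 9000 nM to 60000 nM and could also turn out to be only a limit.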

Compound 3, concentration for 50% growth inhibition: > 30000 nM
Compound 3 ended at the assay's limit (the forecaster's own chance of this, stated with the estimate: 45%); middle value at least 1.2-fold (0.07 log units) from the limit.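

Within the data shown here, no step from compound 1 to compound 3 can be read in this assay, since both values are limits of the assay and not numbers: the limit of > 30000 nM in this assay, at which 2 of the 3 values shown sit. The compounds shown leave open whether hydrogen in place of isopropylcarbonyl on a nitrogen on an aromatic ring changes growth inhibition at all.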